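The source may hold more compounds than are shown below. What is called first, only, known or untested is meant among the compounds shown, and "the series" means these compounds.

Compound 3 `COc1cccc2cc(C(=O)NCNC(=O)CCN(O)C=O)oc12` gives the highest number of the three in an assay on CHO cells for inhibition of bone morphogenetic protein 1 (Homo sapiens), with stated times of 10 min and 60 min (a higher number here means a weaker inhibitor, a lower number a stronger inhibitor), at 6300 nM. Compound 2 `CCC[C@H](CN(O)C=O)C(=O)NCNC(=O)c1cc2cccc(OC)c2o1`, which carries propyl on the saturated chain carbon bound to a carbonyl carbon and a saturated chain carbon, gives 1250 nM. Compound 1 `CCCCC[C@H](CN(O)C=O)C(=O)NCNC(=O)c1ccc(-c2cccc(C(=O)O)c2)o1`, with pentyl there but a different core, gives 8 nM. Compound 4 `COc1cccc2cc(C(=O)NCNC(=O)[C@H](Cc3ccccc3)CN(O)C=O)oc12` differs from compound 3 by benzyl in place of hydrogen on a saturated chain carbon bound to a carbonyl carbon and a saturated chain carbon. Among the measured compounds shown here, the one step that bears on this change is a 5.0-fold higher number from compound 2 to compound 3 (0.70 log units; beyond the scatter): removing propyl from that carbon raised the number, so placing benzyl there is expected to lower it, by at least that much. The expected step is a 21-fold lower number from compound 3 to compound 4 (1.32 log units; beyond the scatter). Compound 4 is therefore estimated at 300 nM, within 60 nM to 1500 nM.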

Compound 4, half-maximal inhibitory concentration: 160 nM
For compound 4 the middle estimate is 1.9-fold (0.27 log units) above the measured one, and the stated range covers the measured number.
By their numbers in this assay, from the lowest: compound 1; then compound 4; then compound 2; then compound 3.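

On the shared core in this assay, benzyl in place of hydrogen at this carbon gives a 39-fold lower number from compound 3 to compound 4 (1.60 log units; beyond the scatter), so the lower number seen with propyl is not unique to that group. Benzyl and propyl also differ from each other beyond the scatter, with a 7.8-fold lower number from compound 2 to compound 4 (0.89 log units; beyond the scatter), showing that the identity of the group at this carbon matters and not just its presence. No evidence here explains either step. On these data alone, whether an amine or cyclohexylmethyl at this carbon would also lower the number remains open. So does whether benzyl would do the same on the core of compound 1.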